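Cyano for Fluoro: What to Expect of Compound 3

The compounds below may be only part of what the source reports. "The series", "measured", "known", "first", "only" and "open" are said of these compounds alone.

Compound 1 `Cc1ccc(Nc2nc(N)nc(COc3cc(N4CCCC4=O)cc(C(F)(F)F)c3)n2)cc1Cl`: 3190 nM
Compound 2 `Cc1ccc(Nc2nc(N)nc(COc3cc(F)cc(N4CCCC4=O)c3)n2)cc1Cl`: 1800 nM

In an assay on COS-7 cells for agonist activity at Free fatty acid receptor 1 (Homo sapiens), read by scintillation counting and inositol phosphate accumulation, with a stated time of 90 min (on this read-out lower numbers stand for an effect already at smaller amounts and higher numbers for an effect only at larger amounts of compound), compound 2 gives 1800 nM, the lower of the two numbers shown. For the measured compounds named here, the single measured step, a 1.8-fold lower number from compound 1 to compound 2 (0.25 log units; within the scatter), lies within the scatter, so the two compounds are not separated. Compound 3 `Cc1ccc(Nc2nc(N)nc(COc3cc(C#N)cc(N4CCCC4=O)c3)n2)cc1Cl` differs from compound 2 by cyano in place of fluoro on an aromatic carbon. No measured step exchanges fluoro for cyano, so nothing shown bears directly on this change, and the one step available was small. A change no larger than the scatter is therefore expected, no change at the digits printed from compound 2 to compound 3 (within the scatter). Compound 3 is estimated at 1800 nM, with a range from 600 nM to 5400 nM.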

Compound 3, half-maximal effective concentration: 4170 nM
Beside the measured number, compound 3's estimate is 2.3-fold (0.36 log units) below it; the range from low to high includes it.
By their numbers in this assay, from the lowest: compounds 2, 1 and 3 (each within the scatter of the next, the first and the last beyond it).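

In this assay, for the compounds shown here, this position, on an aromatic carbon meta to a 2-oxopyrrolidin-1-yl group, responds to the exchange: cyano in place of fluoro gives a 2.3-fold higher number from compound 2 to compound 3 (0.36 log units; beyond the scatter), the first step here to pass the scatter. Cyano in place of trifluoromethyl gives a 1.3-fold higher number from compound 1 to compound 3 (0.12 log units; within the scatter), so those two groups are not separated, and fluoro stands apart from cyano alone. Nothing given here accounts for this result.

As far as these compounds go, whether an amine, a carboxylic acid or a methoxy group at this position would give a lower number than compound 2 remains open.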